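Series notes: ring-amide nitrogen substituents and activity

The source may report more compounds than this note shows. Statements on the series, on what has been measured and on what is new or still open speak of the compounds shown alone.

Measured so far:
- compound 1 `CC(C)[C@@H]1CC[C@@H](C)C[C@@]12N(C)C(=O)[C@@H]1[C@H]3C(=O)NC(=O)[C@H]3ON12`, in a functional assay, read by spectrophotometry, with a stated time of 2 h, tested at 2 mg/mL (on this read-out higher numbers stand for a stronger effect at the one concentration tested and lower numbers for a weaker effect), compound 1 gives 37.1%
- compound 2 `CC(C)[C@@H]1CC[C@@H](C)C[C@@]12N(C)C(=O)[C@@H]1[C@H]3C(=O)N(C)C(=O)[C@H]3ON12`, in this assay compound 2 gives 49.7%
- compound 3 `Cc1cccc(N2C(=O)[C@H]3[C@H](ON4[C@@H]3C(=O)N(C)[C@@]43C[C@H](C)CC[C@H]3C(C)C)C2=O)c1`, in this assay compound 3 gives 43.6%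

Three compounds share one core and differ only at an amide-type nitrogen in a ring. On the numbers shown, compound 3 stands second highest of three; its nearest neighbour is compound 2, a number 6.1 percentage points lower from compound 2 to compound 3 (within the scatter), and its furthest is compound 1, a number 6.5 percentage points higher from compound 1 to compound 3 (within the scatter). For the measured compounds named here, the one step beyond the scatter is a number 12.6 percentage points higher from compound 1 to compound 2 (beyond the scatter).

Compound 4 `Cc1ccc(N2C(=O)[C@H]3[C@H](ON4[C@@H]3C(=O)N(C)[C@@]43C[C@H](C)CC[C@H]3C(C)C)C2=O)c(C)c1` is not yet measured. It differs from compound 3 as follows: 2,4-dimethylphenyl in place of 3-methylphenyl on an amide-type nitrogen in a ring. Going by the values given here, no measured step replaces one aryl group by another; the steps that touch this nitrogen replace hydrogen or methyl by 3-methylphenyl, and both of those are within the scatter. The data therefore give no ground for expecting a step beyond the scatter in this assay in either direction. For compound 4 the estimate is 44%, with a range from 30% to 58%. This estimate means an expected step of a number 0.4 percentage points higher from compound 3 to compound 4 (within the scatter), within the scatter.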

Compound 4, a percentage reported as activity, at one concentration (the size of the read-out at that concentration, not a potency): 57%
Compound 4: middle estimate off by 13 percentage points, on the low side; the measured number falls inside the stated range.
By their numbers in this assay, from the lowest: compounds 1, 3, 2 and 4 (each within the scatter of the next, the first and the last beyond it).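

In this assay, for the compounds shown here, the choice of aryl group on this amide-type nitrogen in a ring now proves to matter: the first aryl-for-aryl step at this position, 2,4-dimethylphenyl in place of 3-methylphenyl, gives a number 13.4 percentage points higher from compound 3 to compound 4 (beyond the scatter). The 2,4-dimethylphenyl group also separates from the hydrogen at this nitrogen, with a number 19.9 percentage points higher from compound 1 to compound 4 (beyond the scatter), which the 3-methylphenyl group did not do within the printed steps. Against the small methyl group there is still no such separation, at a number 7.3 percentage points higher from compound 2 to compound 4 (within the scatter), so a substituted aryl group at this nitrogen has not been shown to exceed methyl on this read-out.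

No measurement on hand explains why the 2,4-dimethylphenyl group differs from the 3-methylphenyl group. From the compounds shown here alone, the step changes the number and the placing of the methyl groups together, so the part each plays stays open, and 2-methylphenyl, 4-methylphenyl, unsubstituted phenyl or a 4-methoxyphenyl group at the same nitrogen would be needed to tell whether the effect follows one methyl group or the pair.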